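Cytotoxicity notes: amide in place of ketone on the core

A few compounds are considered here, and "the series" means these few. Any claim that something is new, unique, unknown or untested is made for them only; others in the source may bear on it.

Compound 1 `Cn1c(Cc2ccccc2C(F)(F)F)nc(C(=O)CCc2ccccc2)c(O)c1=O` carries a phenethyl group on the carbonyl carbon of the shared core. In an ADME assay on HepG2 cells (Homo sapiens) for cytotoxicity, in the presence of a further agent that is not named here (on this read-out higher numbers stand for weaker inhibition and lower numbers for stronger inhibition), compound 1 gives > 100000 nM, which is a limit of the assay and not a number. Within the data shown here, compound 2 `CC(c1ccccc1C(F)(F)F)c1nc(C(=O)NCc2ccccc2)c(O)c(=O)n1C` is the only other measured member of the series. In this assay compound 2 gives > 100000 nM, again a limit rather than a number. Both shown values sit at the same limit (the limit of > 100000 nM in this assay, at which 2 of the 2 values shown sit), so compound 1 cannot be set apart from compound 2 on the numbers shown. Compound 3 `CC(NC(=O)c1nc(Cc2ccccc2C(F)(F)F)n(C)c(=O)c1O)c1ccccc1` is not yet measured. It differs from compound 1 as follows ((1-phenylethyl)amino in place of phenethyl on a carbonyl carbon). Among the measured compounds shown here, no measured step between compounds is available. Because both shown values sit at the limit (the limit of > 100000 nM in this assay, at which 2 of the 2 values shown sit), the change in this assay is expected to be none beyond the scatter. The estimated step is a number no higher from compound 1 to compound 3 (the limit leaves the size open). For compound 3 the expected value in this assay is 100000 nM, with a range from 40000 nM to 300000 nM, most likely reported as a limit.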

Compound 3, half-maximal inhibitory concentration: > 100000 nM
Compound 3: only a limit was reported (the forecaster's own chance of this, stated with the estimate: 85%); the middle value lies on the limit itself.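

Among these compounds, no step from compound 1 to compound 3 can be read, because the result for compound 3 is a limit and not a number, as is that for compound 1: the limit of > 100000 nM in this assay, at which 3 of the 3 values shown sit.

In this assay the compounds shown leave open whether any change on the carbonyl carbon gives a value short of this limit.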